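A few compounds are considered here, and "the series" means these few. Any claim that something is new, unique, unknown or untested is made for them only; others in the source may bear on it.

Measured compounds and their values in a functional assay on the whole organism (Hindlimb) for inhibition, with Mus musculus as the target, with a stated time of 4 h; on this read-out lower numbers stand for an effect already at smaller amounts and higher numbers for an effect only at larger amounts of compound:

compound 1, `CC1(C)CC12NC(=O)N(NC(=O)c1ccc(F)cc1)C2=O`: 300 mg/kg
compound 2, `CC1(C)CC12NC(=O)N(NC(=O)c1ccco1)C2=O`: 300 mg/kg
compound 3, `CC1(C)CC12NC(=O)N(NC(=O)c1ccncc1)C2=O`: 300 mg/kg

All three share one core and differ only in the aromatic group attached to the carbonyl carbon of the side chain. In this assay compound 1 gives 300 mg/kg, compound 2 gives 300 mg/kg, and compound 3 gives 300 mg/kg. Compound 3 therefore stands level with the other two: the step of no change at the digits printed from compound 1 to compound 3 (within the scatter) and the step of no change at the digits printed from compound 2 to compound 3 (within the scatter) both show no difference, and the same holds for no change at the digits printed from compound 1 to compound 2 (within the scatter). Swapping one aromatic group for another on that carbonyl carbon has so far left the read-out untouched.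

Compound 4, `CC1(C)CC12NC(=O)N(NC(=O)c1cccnc1)C2=O`, is the next member of the series. It differs from compound 3 in one place: pyridin-3-yl in place of pyridin-4-yl on a carbonyl carbon. Among the compounds with values here, this is the smallest change yet, a move of the ring nitrogen within the same six-membered aromatic ring, and the three measured steps, all flat, are the only guide available. On that basis the step of no change at the digits printed from compound 3 to compound 4 (within the scatter) is expected to stay within the scatter. Compound 4 is estimated at 300 mg/kg in this assay, within a range from 150 mg/kg to 600 mg/kg.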

Compound 4, minimum effective dose: 300 mg/kg
The estimate for compound 4 equals the measured number at the digits printed; the measured number falls inside the stated range.
By their numbers in this assay, from the lowest: compounds 1, 2, 3 and 4 (each within the scatter of the next).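

In this assay, within the data shown here, moving the ring nitrogen from pyridin-4-yl to pyridin-3-yl on a carbonyl carbon gives no change at the digits printed from compound 3 to compound 4 (within the scatter), so the position of that nitrogen within the ring makes no visible difference here, something the earlier compounds could not show. Setting pyridin-3-yl against the other two groups gives no change at the digits printed from compound 2 to compound 4 (within the scatter) for furan-2-yl and no change at the digits printed from compound 1 to compound 4 (within the scatter) for 4-fluorophenyl, which means all four aromatic groups at this place now stand level, with no compound going against that pattern. No measurement shown offers an explanation for this flat picture.

On these data alone, all four groups are aromatic rings on that carbonyl carbon, so it remains open whether a cyclohexyl ring, a longer alkyl chain or an amine in their place would give the same minimum effective dose. As far as these compounds go, it also remains open whether a carboxylic acid or a methoxy group added to one of these rings would move the read-out at all.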